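Moving the Trifluoromethyl Group on the Benzamide Ring

The compounds below may be only part of what the source reports. "The series", "measured", "known", "first", "only" and "open" are said of these compounds alone.

Three compounds have been measured in a functional assay on HL-60 cells (Homo sapiens) for antiproliferative activity, with a stated time of 24 h; on this read-out lower numbers stand for stronger inhibition and higher numbers for weaker inhibition:

compound 1 `NC(=O)c1c(NC(=O)c2ccc(C(F)(F)F)cc2)sc2c1CCN(Cc1c(Cl)cccc1Cl)C2`: 10600 nM
compound 2 `NC(=O)c1c(NC(=O)c2ccccc2F)sc2c1CCN(C(=S)Nc1ccccc1Cl)C2`: 12500 nM
compound 3 `NC(=O)c1c(NC(=O)c2ccccc2C(F)(F)F)sc2c1CCN(C(=S)Nc1ccccc1Cl)C2`: 17600 nM

Compound 3 stands highest of the three numbers. Among the compounds with values here, its nearest neighbour is compound 2, and the only single-point step among the measured compounds, a 1.4-fold higher number from compound 2 to compound 3 (0.15 log units; within the scatter), lies within the scatter. Compound 1 is the furthest from compound 3, but the two values are also within the scatter of each other, so the three compounds cannot be ordered.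

Compound 4 `NC(=O)c1c(NC(=O)c2ccc(C(F)(F)F)cc2)sc2c1CCN(C(=S)Nc1ccccc1Cl)C2` differs from compound 3 in one place: 4-(trifluoromethyl)phenyl in place of 2-(trifluoromethyl)phenyl on a carbonyl carbon. Within the data shown here, no measured step covers this move of the trifluoromethyl group. Compound 1 carries the same 4-(trifluoromethyl)phenyl group, but on a core with a different substituent on the ring nitrogen, so its value shows only where that combination lies, not the effect of the move itself. Among the measured compounds shown here, the one step that is known, a 1.4-fold higher number from compound 2 to compound 3 (0.15 log units; within the scatter), was within the scatter. The step to compound 4 is therefore expected to be a 1.4-fold lower number from compound 3 to compound 4 (0.13 log units; within the scatter), none beyond the scatter. For compound 4 the estimate in this assay is 13000 nM, with a range from 6000 nM to 28000 nM.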

Compound 4, half-maximal inhibitory concentration: 36100 nM
Compound 4: middle estimate off by 2.8-fold (0.44 log units), on the low side; the measured number lies above the stated range.
By their numbers in this assay, from the lowest: compounds 1, 2 and 3 (each within the scatter of the next); then compound 4.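

In this assay, moving the trifluoromethyl group from 2-(trifluoromethyl)phenyl to 4-(trifluoromethyl)phenyl on the carbonyl carbon gives a 2.1-fold higher number from compound 3 to compound 4 (0.31 log units; beyond the scatter) and so makes a modest difference, even though the atoms stay the same. The 4-(trifluoromethyl)phenyl group also separates from 2-fluorophenyl, with a 2.9-fold higher number from compound 2 to compound 4 (0.46 log units; beyond the scatter) in this series, whereas the earlier step of a 1.4-fold higher number from compound 2 to compound 3 (0.15 log units; within the scatter) did not separate the two groups at all. With 4-(trifluoromethyl)phenyl held fixed, the group on the amine nitrogen in a ring also counts, as a 3.4-fold higher number from compound 1 to compound 4 (0.53 log units; beyond the scatter) shows.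

From the compounds shown here alone, whether an amine or a carboxylic acid in place of the trifluoromethyl group would shift the number remains open, as does whether the same move would give a similar step on the core of compound 1. Nothing available explains why these steps arise.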